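The source may hold more compounds than are shown below. What is called first, only, known or untested is meant among the compounds shown, and "the series" means these compounds.

Compound 3 `Cn1ncc2c(NC(=O)NCc3cc(C(C)(C)C)nn3-c3cccc(C(F)(F)F)c3)cccc21` gives 0.6 nM in an assay on CHO-K1 cells for antagonist activity at transient receptor potential cation channel subfamily V member 1 (Homo sapiens), read by FLIPR and calcium flux, with a stated time of 6 min (on this read-out lower numbers stand for stronger inhibition and higher numbers for weaker inhibition), the second highest of the three numbers measured. Compound 2 `CC(C)(C)c1cc(CNC(=O)Nc2cccc3[nH]ncc23)n(-c2cccc(C(F)(F)F)c2)n1` gives 0.3 nM in this assay, and compound 1 `Cn1ncc2c(NC(=O)NCc3cc(C(F)(F)F)nn3-c3cccc(C(F)(F)F)c3)cccc21` gives 1.4 nM. The two measured steps are a 2.3-fold lower number from compound 1 to compound 3 (0.37 log units; beyond the scatter) and a 2.0-fold higher number from compound 2 to compound 3 (0.30 log units; within the scatter). Compound 4 `Cn1ncc2c(NC(=O)NCc3cc(C(C)(C)C)nn3-c3ccc(F)c(F)c3)cccc21` differs from compound 3 by 3,4-difluorophenyl in place of 3-(trifluoromethyl)phenyl on an aromatic nitrogen. Neither measured step touches the aryl group on that ring nitrogen, since compounds 1, 2 and 3 all carry the same 3-(trifluoromethyl)phenyl there, so no direct guide exists, and the shared core with its urea and tert-butyl is kept. Compound 4 is therefore expected to weaken modestly, a 3.3-fold higher number from compound 3 to compound 4 (0.52 log units; beyond the scatter), to an estimated 2 nM with a range of 0.6 nM to 8 nM.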

Compound 4, inhibition constant: 1 nM
Beside the measured number, compound 4's estimate is 2.0-fold (0.30 log units) above it; measured number inside the range.
By their numbers in this assay, from the lowest: compounds 2, 3, 4 and 1 (each within the scatter of the next, the first and the last beyond it).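

In this assay, going by these compounds alone, the aryl group on the aromatic nitrogen, the same in all the earlier compounds, is now varied, and 3,4-difluorophenyl in place of 3-(trifluoromethyl)phenyl gives a 1.7-fold higher number from compound 3 to compound 4 (0.22 log units; within the scatter) and so no change that can be told from the scatter. With the tert-butyl group and the rest of the shared core kept, this pair therefore shows no need for the trifluoromethyl group at this place. Nothing shown accounts for this result.

From the compounds shown here alone, what a pyridine, an unsubstituted phenyl or a methoxyphenyl would give at this place remains open. So does whether 3,4-difluorophenyl behaves the same way alongside the trifluoromethyl group of compound 1.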